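The compounds below may be only part of what the source reports. "The series", "measured", "known", "first", "only" and "open" are said of these compounds alone.

Compound 1 `Fc1ccccc1-c1nc(Cc2c[nH]c3ccccc23)no1` and compound 2 `COc1cc(-c2noc(-c3ccccc3)n2)cc(OC)c1OC` have both been run in a functional assay on cells (Splenocyte, Mus musculus, strain BALB/c) for inhibition, read by scintillation counting and thymidine incorporation, with stated times of 48 h and 8 h; a lower number here means a stronger inhibitor, a higher number a weaker inhibitor. In this assay compound 1 gives > 50000 nM, which is a limit of the assay and not a number. In this assay compound 2 likewise gives > 50000 nM, again only a limit. Compound 2 thus stands at the limit of > 50000 nM in this assay, at which 2 of the 2 values shown sit, with no numerical value to place it. Compound 3 `CCCCc1ccc(-c2nc(-c3cc(OC)c(OC)c(OC)c3)no2)cc1` differs from compound 2 by butyl in place of hydrogen on an aromatic carbon. Among the measured compounds shown here, no step between measured compounds is available, so no shift beyond the usual scatter is expected in this assay. The expected step is a number no higher from compound 2 to compound 3 (the limit leaves the size open). Compound 3 is expected to give 50000 nM in this assay, within 10000 nM to 200000 nM, most likely again reported only as a limit.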

Compound 3, half-maximal inhibitory concentration: 36200 nM
Compound 3: middle estimate off by 1.4-fold (0.14 log units), on the high side; the measured number falls inside the stated range.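

In this assay, among the compounds shown here, butyl in place of hydrogen on an aromatic carbon, para to a large group, yields the first numerical value, as compound 3 gives 36200 nM rather than a limit. Compound 2 remains a limit and not a number, as does compound 1: the limit of > 50000 nM in this assay, at which 2 of the 3 values shown sit. The change is an at least 1.3-fold lower number from compound 2 to compound 3 (0.14 log units; that floor lies within the scatter) and its true size cannot be read, so this position accepts butyl without any gain being established. Going by these compounds, whether a longer chain, an amine or a carboxylic acid at this carbon would move the number beyond the scatter remains open.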